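Isomeric pyridyl swap on the imidazopyridine of compound 2

A few compounds are considered here, and "the series" means these few. Any claim that something is new, unique, unknown or untested is made for them only; others in the source may bear on it.

Measured so far:
Compound 1 `Cc1cc(-c2c(C)nn(C)c2C)cnc1-c1nnc(N(C)Cc2ccc3ncc(-c4cccc(CN(C)C)c4)n3c2)o1`: 3
Compound 2 `Cc1cc(-c2c(C)nn(C)c2C)cnc1-c1nnc(N(C)Cc2ccc3ncc(-c4ccc(CN(C)C)nc4)n3c2)o1`: 2.5

Two compounds share the same core and differ only in the aryl group on the fused bicyclic system. In a physicochemical assay for lipophilicity, at pH 7.4 (a higher number here means a more lipophilic compound, a lower number a more polar compound), compound 1 gives 3. In this assay, going by the values given here, compound 2 gives 2.5, which is the lower of the two numbers; the one step known, a number 0.50 log units lower from compound 1 to compound 2 (beyond the scatter), is modest but lies beyond the scatter.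

Compound 3 `Cc1cc(-c2c(C)nn(C)c2C)cnc1-c1nnc(N(C)Cc2ccc3ncc(-c4ccc(CN(C)C)cn4)n3c2)o1` has not yet been measured in this assay. It differs from compound 2 in one place: 5-((dimethylamino)methyl)pyridin-2-yl in place of 6-((dimethylamino)methyl)pyridin-3-yl on an aromatic carbon. The two compounds have the same atoms, joined differently, and the group that enters keeps the same count of heavy atoms, donors and acceptors as the one that leaves.

Among the compounds with values here, no measured step concerns such a rearrangement within a pyridyl ring; the only known step, from compound 1 to compound 2, exchanges a phenyl for a pyridyl and is therefore of a different kind. Within the data shown here, with no direct precedent, the step expected for compound 3, no change at the digits printed from compound 2 to compound 3 (within the scatter), is none beyond the scatter. Compound 3 is accordingly estimated at 2.5, with a range from 2 to 3.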

Compound 3, distribution coefficient: 3
Estimate against measurement, compound 3: 0.50 log units below; the range from low to high includes it.
By their numbers in this assay, from the lowest: compound 2; then compounds 1 and 3 (each within the scatter of the next).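

In this assay the placement of the ring nitrogen in the pyridyl group on this aromatic carbon proves to matter: the two isomers share the same atoms and the same counts of donors and acceptors, yet the change gives a number 0.50 log units higher from compound 2 to compound 3 (beyond the scatter) on the same core. Exchanging the phenyl for a pyridyl therefore does not carry one fixed step here, since the 6-((dimethylamino)methyl)pyridin-3-yl group gave a number 0.50 log units lower from compound 1 to compound 2 (beyond the scatter) while the 5-((dimethylamino)methyl)pyridin-2-yl group gives no change at the digits printed from compound 1 to compound 3 (within the scatter) in the same exchange. The data shown offer no measurement that accounts for the gap between the two isomers.

All three aryl groups carry the same dimethylaminomethyl side chain, so this effect of nitrogen placement rests on a single pair of isomers. Going by these compounds, whether a morpholine or a primary amine in place of the dimethylamino group, or a pyrimidine ring in place of the pyridine, would keep that gap remains open.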